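The compounds below may be only part of what the source reports. "The series", "measured", "known", "first", "only" and "open" are said of these compounds alone.

Measured so far in a functional assay on DU-145 cells (Homo sapiens) for cytotoxicity, read by MTT assay, with a stated time of 72 h; a lower number here means a stronger inhibitor, a higher number a weaker inhibitor:
- compound 1 `Cc1cc(/C=C/c2ccc(O)cc2)[nH]n1` gives 45800 nM
- compound 2 `COc1ccc(/C=C/c2cc(C)n[nH]2)cc1` gives 8400 nM
- compound 3 `COc1ccc(/C=C/c2cc(C)no2)cc1` gives > 100000 nM

The entry for compound 3 is a limit and not a number. Of the two actual numbers, compound 1 holds the higher, and the modest step to the other is a 5.5-fold lower number from compound 1 to compound 2 (0.74 log units; beyond the scatter) on a ring oxygen. Among the measured compounds shown here, compound 4 `Cc1cc(/C=C/c2ccc(O)c(O)c2)[nH]n1` differs from compound 1 by hydroxy in place of hydrogen on an aromatic carbon and no measured step makes this same change. The methyl step above therefore serves only as a rough guide to size. The estimated step is a 2.3-fold lower number from compound 1 to compound 4 (0.36 log units; beyond the scatter) and is expected to be modest, towards a lower number with low confidence in direction. For compound 4 the expected value is 20000 nM within an estimated range of 6000 nM to 70000 nM.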

Compound 4, half-maximal inhibitory concentration: 33100 nM
Compound 4: the middle estimate sits 1.7-fold (0.22 log units) below what was measured, within the range that was stated.
By their numbers in this assay, from the lowest: compound 2; then compounds 4 and 1 (each within the scatter of the next). At a limit, above all of these: compound 3.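

In this assay the hydroxy group added on the aromatic carbon, ortho to the existing hydroxy group, gives a 1.4-fold lower number from compound 1 to compound 4 (0.14 log units; within the scatter) and so produces no readable shift. Unlike the earlier step on the ring oxygen, this is a change on a ring carbon, and here the series shows no response to the new group. Nothing measured here accounts for this result.

Open, as far as these compounds go, is whether an amine or a fluorine at the same carbon would move the number. Also open, from the compounds shown here alone, is whether the added hydroxy group would read the same on compound 2.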